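The source may hold more compounds than are shown below. What is called first, only, known or untested is meant among the compounds shown, and "the series" means these compounds.

Measured compounds in an ADME assay on HEp-2 cells (Homo sapiens) for cytotoxicity, read by CCK-8 assay, with a stated time of 5 days; a higher number here means that more compound is tolerated, a lower number that less compound is tolerated:
compound 1, `NCCCCNc1cc(N2CCc3ccccc3C2)nc2ccccc12`: compound 1 gives 7400 nM
compound 2, `Cc1ccc2nc(N3CCCc4ccccc4C3)cc(NCCN)c2c1`: compound 2 gives 9400 nM
compound 3, `Cc1ccc2nc(N3CCCc4ccc(F)cc4C3)cc(NCCN)c2c1`: compound 3 gives > 3200 nM, which is a limit of the assay and not a number

Compound 3 stands only at a limit in this assay, namely (the limit of > 3200 nM in this assay, at which 1 of the 3 values shown sits); where it falls against compound 1 and compound 2 cannot be read. Compound 4, `Cc1ccc2nc(N3CCCc4ccc(F)cc4C3)cc(NCC(C)N)c2c1`, differs from compound 3 by methyl in place of hydrogen on a saturated chain carbon bound to an amine nitrogen and a saturated chain carbon. Among the measured compounds shown here, no measured pair carries this change. For the measured compounds named here, the one step that touches compound 3, a step that the limit leaves unreadable from compound 2 to compound 3, is itself unreadable, so it gives no size for this assay. Going by the values given here, compound 1 and compound 2 show that the series as a whole sits in the micromolar region, and nothing among the measured compounds points to a move in either direction for a methyl on the chain. Expected is therefore no step beyond the scatter: a step that the limit leaves unreadable from compound 3 to compound 4, with a real chance that the assay again returns only a limit. The estimate for compound 4 in this assay is 6000 nM, between 2500 nM and 15000 nM.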

Compound 4, half-maximal cytotoxic concentration: 86000 nM
For compound 4 the middle estimate is 14-fold (1.16 log units) below the measured one; the whole stated range lies below it.
By their numbers in this assay, from the lowest: compounds 1 and 2 (each within the scatter of the next); then compound 4.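

In this assay no new step can be read from compound 3 to compound 4, since compound 3 stands only at a limit: the limit of > 3200 nM in this assay, at which 1 of the 4 values shown sits.

The compounds shown leave open the size and direction of the change from methyl in place of hydrogen on this saturated chain carbon.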